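Lengthening the chain: from compound 3 to compound 4

A few compounds are considered here, and "the series" means these few. Any claim that something is new, unique, unknown or untested is made for them only; others in the source may bear on it.

The compounds share one core and differ in the length of the saturated chain. In a functional assay on SW480 cells (Homo sapiens) for antiproliferative activity, read by MTT assay, with a stated time of 48 h (a lower number here means a stronger inhibitor, a higher number a weaker inhibitor), compound 1 `CCCCCC(CCO)n1cnc2c(Cl)nc(F)nc21` gives 7440 nM, compound 2 `CCCCCCC(CCO)n1cnc2c(Cl)nc(F)nc21` gives 12900 nM and compound 3 `CCCCCCCC(CCO)n1cnc2c(Cl)nc(F)nc21` gives 26100 nM. Compound 3 therefore carries the highest number of the three and is the weakest inhibitor so far, with its gaps to both others beyond the scatter.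

Compound 4 `CCCCCCCCC(CCO)n1cnc2c(Cl)nc(F)nc21` has not yet been measured. The change is methyl in place of hydrogen on a saturated chain carbon, eight bonds along the chain from an aromatic nitrogen.

The nearest precedents are the same methyl-for-hydrogen replacement made six and seven bonds along the chain: a 1.7-fold higher number from compound 1 to compound 2 (0.24 log units; within the scatter) and a 2.0-fold higher number from compound 2 to compound 3 (0.31 log units; beyond the scatter). The first lies within the scatter and the second just beyond it. The ethyl-for-hydrogen replacement gives a 3.5-fold higher number from compound 1 to compound 3 (0.55 log units; beyond the scatter), which confirms the direction over the wider span. Three compounds cannot show whether this continues, but none of them goes against it. Another modest move towards a higher number in this assay is therefore expected, similar in size to the two methyl steps. The expected change is a 1.8-fold higher number from compound 3 to compound 4 (0.26 log units; within the scatter). For compound 4 the estimated value is 47000 nM, with an expected range of 27000 nM to 95000 nM.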

Compound 4, half-maximal inhibitory concentration: 15000 nM
Compound 4: the middle estimate sits 3.1-fold (0.50 log units) above what was measured; the whole stated range lies above it.
By their numbers in this assay, from the lowest: compounds 1, 2, 4 and 3 (each within the scatter of the next, the first and the last beyond it).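

In this assay the climb in the number does not carry on at eight bonds along the chain from an aromatic nitrogen (a 1.7-fold lower number from compound 3 to compound 4 (0.24 log units; within the scatter)), so the methyl-for-hydrogen change does not behave alike at every chain length: the same change on two cores in this assay, a 1.7-fold higher number (0.24 log units; within the scatter) from compound 1 to compound 2 and a 1.7-fold lower number (0.24 log units; within the scatter) from compound 3 to compound 4, 3.0-fold (0.48 log units) apart, beyond the scatter of two such steps

The ethyl-for-hydrogen change, made seven bonds along the chain, likewise gives a much smaller step (a 1.2-fold higher number from compound 2 to compound 4 (0.07 log units; within the scatter)) than it gave six bonds along the chain: the same change on two cores in this assay, a 3.5-fold higher number (0.55 log units; beyond the scatter) from compound 1 to compound 3 and a 1.2-fold higher number (0.07 log units; within the scatter) from compound 2 to compound 4, 3.0-fold (0.48 log units) apart, beyond the scatter of two such steps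

Even the propyl-for-hydrogen change over the whole span stays within the scatter (a 2.0-fold higher number from compound 1 to compound 4 (0.30 log units; within the scatter)), so the steady rise seen across compound 1, compound 2 and compound 3 holds for those three alone, and compound 4 goes against it.

Among these compounds, with only one compound beyond compound 3, it remains open whether the number levels off, turns back or simply scatters in this range with a longer chain. Also open, going by these compounds, is how the series responds to an amine or a carboxylic acid in place of the hydroxyl on the shared core.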